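Chloro for hydroxy on a weak growth inhibitor

A few compounds are considered here, and "the series" means these few. Any claim that something is new, unique, unknown or untested is made for them only; others in the source may bear on it.

Measured compounds:
compound 1 `COc1cc2c(/C=C3/C(=O)Nc4ccc(O)cc43)c(Cl)n(Cc3cc(OC)c(OC)c(OC)c3)c2cc1C` — 34700 nM
compound 2 `O=C1Nc2ccccc2/C1=C\c1c(Cl)n(Cc2ccccc2)c2ccccc12` — 47900 nM

In a functional assay on cells (Cancer cell lines, Homo sapiens) for cytotoxicity, with a stated time of 48 h (a higher number here means a weaker inhibitor of growth, a lower number a stronger inhibitor of growth), compound 1 gives 34700 nM and compound 2 gives 47900 nM. The two numbers lie within the usual scatter of each other, so compound 1 is not set apart from compound 2 in this assay. Compound 3 `COc1cc2c(/C=C3/C(=O)Nc4ccc(Cl)cc43)c(Cl)n(Cc3cc(OC)c(OC)c(OC)c3)c2cc1C` is not yet measured; it differs from compound 1 by chloro in place of hydroxy on an aromatic carbon. Within the data shown here, no step between measured compounds speaks to this change, so no shift beyond the scatter is expected in this assay. For compound 3 the expected result is 32000 nM, in the range 11000 nM to 95000 nM. This estimate means a step of a 1.1-fold lower number from compound 1 to compound 3 (0.04 log units; within the scatter), expected to remain within the scatter.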

Compound 3, concentration for total growth inhibition: 6030 nM
Beside the measured number, compound 3's estimate is 5.3-fold (0.72 log units) above it, and the stated range ends above it.
By their numbers in this assay, from the lowest: compound 3; then compounds 1 and 2 (each within the scatter of the next).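

Chloro in place of hydroxy on this aromatic carbon gives a 5.8-fold lower number from compound 1 to compound 3 (0.76 log units; beyond the scatter) in this assay, the first change shown at this position and one that moves the result beyond the scatter. Exchanging this single heavy atom is therefore enough to give a stronger inhibitor of growth on the shared core. Nothing measured here accounts for the shift. As far as these compounds go, whether the gain comes from adding chloro or from removing hydroxy stays open. The compounds shown also do not tell how fluoro, methoxy or an amine would read at this carbon.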